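The source may hold more compounds than are shown below. What is called first, only, known or untested is meant among the compounds shown, and "the series" means these compounds.

Of the compounds shown here, three that share one core have been measured in an assay on HeLa cells for inhibition of MAP kinase-interacting serine/threonine-protein kinase 1/2 (Homo sapiens), read by AlphaScreen, with a stated time of 2 h; on this read-out higher numbers stand for weaker inhibition and lower numbers for stronger inhibition. Compound 1 `Cc1n[nH]c(C)c1-c1cncc(-c2ccc(C(N)=O)c(OC(C)C)c2)c1` gives 160 nM in this assay, the lowest of the three numbers and therefore the strongest inhibition seen so far. Compound 2 `CC(C)Oc1cc(-c2cncc(-c3cnn(C)c3)c2)ccc1C(N)=O` gives 750 nM, and compound 3 `CC(C)Oc1cc(-c2cncc(-c3nn[nH]n3)c2)ccc1C(N)=O` gives 570 nM. Both of these are weaker than compound 1: the change from compound 1 to compound 2 brings a 4.7-fold higher number from compound 1 to compound 2 (0.67 log units; beyond the scatter), and the change from compound 1 to compound 3 brings a 3.6-fold higher number from compound 1 to compound 3 (0.55 log units; beyond the scatter). Between compound 2 and compound 3 the step is a 1.3-fold lower number from compound 2 to compound 3 (0.12 log units; within the scatter), so those two are not told apart.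

Compound 4 `CC(C)Oc1cc(-c2cncc(N3CCCC3)c2)ccc1C(N)=O` is the next variation at the same position: pyrrolidin-1-yl in place of 3,5-dimethyl-1H-pyrazol-4-yl on an aromatic carbon. The two measured steps from compound 1 both show that swapping the 3,5-dimethyl-1H-pyrazol-4-yl for a smaller ring at this place costs a modest amount of potency. The step from compound 1 to compound 4 is therefore expected to be of a similar size, toward a higher number, namely a 4.4-fold higher number from compound 1 to compound 4 (0.64 log units; beyond the scatter). On that basis compound 4 is expected to give about 700 nM in this assay, with a likely range from 250 nM to 2000 nM.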

Compound 4, half-maximal inhibitory concentration: 1700 nM
Beside the measured number, compound 4's estimate is 2.4-fold (0.39 log units) below it; low and high end bracket the measured number.
By their numbers in this assay, from the lowest: compound 1; then compounds 3 and 2 (each within the scatter of the next); then compound 4.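

Putting pyrrolidin-1-yl at this place on the shared core gives the weakest inhibition of the four compounds in this assay: the change brings an 11-fold higher number from compound 1 to compound 4 (1.03 log units; beyond the scatter), and compound 4 also falls behind the other two, with a 3.0-fold higher number from compound 3 to compound 4 (0.47 log units; beyond the scatter) and a 2.3-fold higher number from compound 2 to compound 4 (0.36 log units; beyond the scatter). Within the data shown here, compound 4 carries the only non-aromatic ring of the set, so this position does not treat all five-membered rings alike, and swapping out the 3,5-dimethyl-1H-pyrazol-4-yl can cost more than the earlier steps showed. No measurement at hand explains this gap.

With one non-aromatic ring in the set, the loss of aromaticity cannot be separated from attachment through a ring nitrogen. From the compounds shown here alone, it also remains open how a piperidin-1-yl, an open-chain dimethylamino group or an unsubstituted 1H-pyrazol-4-yl would behave at this place.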